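Hydroxyalkylsulfonyl chain length and microsomal stability in the series

The source may hold more compounds than are shown below. What is called first, only, known or untested is meant among the compounds shown, and "the series" means these compounds.

Measured so far in an ADME assay (liver, Mus musculus) for metabolic stability, using microsomes, with a stated time of 10 min; a higher number here means that more of the compound is left, a lower number that less of the compound is left:
compound 1, `CCCc1cnc(N2CCC(C3Cc4cc(C5=CCN(S(=O)(=O)CCCO)CC5)cc(F)c4O3)CC2)nc1`: 60%
compound 2, `CCCc1cnc(N2CCC(C3Cc4cc(C5=CCN(S(=O)(=O)CCCCO)CC5)cc(F)c4O3)CC2)nc1`: 59%
compound 3, `CCCc1cnc(N2CCC(C3(C)Cc4cc(C5=CCN(S(=O)(=O)CCCO)CC5)ccc4O3)CC2)nc1`: 42%

Compound 2 is compound 1 with hydroxymethyl in place of hydroxy on a saturated chain carbon, three bonds along the chain from a sulfonyl sulfur; the step in this assay is a number 1 percentage points lower from compound 1 to compound 2 (within the scatter). Compound 3 carries a different core; how its core differs from that of compound 1 is not broken down here. Its value is the lowest of the three, and the gaps to compound 1 and compound 2 are beyond the usual scatter.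

Compound 4, `CCCc1cnc(N2CCC(C3(C)Cc4cc(C5=CCN(S(=O)(=O)CCCCO)CC5)ccc4O3)CC2)nc1`, is compound 3 with hydroxymethyl in place of hydroxy on a saturated chain carbon, three bonds along the chain from a sulfonyl sulfur, the same change as from compound 1 to compound 2. The expected step in this assay is a number 1 percentage points lower from compound 3 to compound 4 (within the scatter), resting on a number 1 percentage points lower from compound 1 to compound 2 (within the scatter). Compound 4 is estimated at 41%, with a likely range from 28% to 54%.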

Compound 4, percent of the compound remaining: 70%
Beside the measured number, compound 4's estimate is 29 percentage points below it, outside the stated range (above it).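

The change from hydroxy to hydroxymethyl gives a number 28 percentage points higher from compound 3 to compound 4 (beyond the scatter) in this assay and does not behave alike on the two cores: the same change on two cores in this assay, a number 1 percentage points lower (within the scatter) from compound 1 to compound 2 and a number 28 percentage points higher (beyond the scatter) from compound 3 to compound 4, 29 percentage points apart, beyond the scatter of two such steps.
The step read on the core of compound 1 therefore cannot stand in for the step on the core of compound 3 in this series. The two steps do not tell which feature of the core of compound 3 goes with the larger step, nor whether that step would recur on a third core.

Open, from the compounds shown here alone, is whether a longer chain, or an amine or a carboxylic acid in place of the hydroxy, would follow the core of compound 1 or that of compound 3. Also open, going by these compounds, is how the same change behaves on a core carrying only part of the difference between these two cores.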